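Salicyl hydrazone series: chloro step and tolerated concentration

This account rests on a few compounds, and the source may have more. Where it says the series, first, only, none or still open, it means among the compounds named here.

compound 1 `Cc1ccc(C(=O)N/N=C/c2ccc(Cl)cc2)c(O)c1`: 116000 nM
compound 2 `COc1cccc(/C=N/NC(=O)c2ccc(C)cc2O)c1`: 672000 nM
compound 3 `Cc1ccc(C(=O)N/N=C/c2ccccc2)c(O)c1`: 578000 nM

All three numbers come from an ADME assay on cells (Mus musculus, strain BALB/C) for cytotoxicity, read by MTT assay, with a stated time of 24 h; a lower number here means that less compound is tolerated, a higher number that more compound is tolerated. Compound 3 stands second highest of the three; compound 2 sits nearest, within the scatter, while compound 1 lies well below it. Compound 4 `Cc1ccc(C(=O)N/N=C/c2ccccc2Cl)c(O)c1` differs from compound 3 by chloro in place of hydrogen on an aromatic carbon. The measured step that bears on this change is the chloro step, a 5.0-fold higher number from compound 1 to compound 3 (0.70 log units; beyond the scatter), a modest drop in tolerated concentration when chloro enters. The methoxy step, a 1.2-fold lower number from compound 2 to compound 3 (0.07 log units; within the scatter), gives no guidance of its own. Because of a 5.0-fold higher number from compound 1 to compound 3 (0.70 log units; beyond the scatter) a lower number is expected for compound 4, though the change now sits ortho to a large group, so the size is uncertain; the estimated step is a 2.6-fold lower number from compound 3 to compound 4 (0.42 log units; beyond the scatter). Compound 4 is expected to give 220000 nM in this assay, with a range of 80000 nM to 600000 nM.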

Compound 4, half-maximal cytotoxic concentration: 125000 nM
Compound 4: the middle estimate sits 1.8-fold (0.25 log units) above what was measured; measured number inside the range.
By their numbers in this assay, from the lowest: compounds 1 and 4 (each within the scatter of the next); then compounds 3 and 2 (each within the scatter of the next).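

In this assay chloro in place of hydrogen ortho to a large group gives a 4.6-fold lower number from compound 3 to compound 4 (0.67 log units; beyond the scatter), so the lowering seen with chloro in compound 1 is not confined to one position on this ring. Compound 1 and compound 4 lie within the scatter of each other, so the two chloro placements are not told apart by this read-out. Nothing measured here accounts for the step. Open, from the compounds shown here alone, is how a group other than chloro, such as an amine or a carboxylic acid, would read at this position. Also open, going by these compounds, is whether a larger halogen such as bromo would follow chloro there.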